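Methylsulfonyl replacement in two cores, compound 4 pending

This account rests on a few compounds, and the source may have more. Where it says the series, first, only, none or still open, it means among the compounds named here.

Compound 1 `COc1ccc(-c2nnc([S+](C)[O-])n2C)cc1` and compound 2 `COc1ccc(-c2nnc(S(C)(=O)=O)n2C)cc1` share one core and differ in a single group. In a functional assay on the whole organism for antagonist activity, with Mus musculus as the target (a higher number here means that more compound is needed for the effect, a lower number that less compound is needed), compound 1 gives > 100 mg/kg, which is a limit of the assay and not a number. In this assay compound 2 gives > 200 mg/kg, likewise a limit rather than a number. The change a group of 4 heavy atoms (1 carbon, 2 oxygen, 1 sulfur; no ring) in place of a group of 3 heavy atoms (1 carbon, 1 oxygen, 1 sulfur; no ring), on an aromatic carbon therefore yields a step that the two limits leave unreadable from compound 1 to compound 2; the step is unreadable because the limit of > 100 mg/kg in this assay, at which 1 of the 3 values shown sits, and the limit of > 200 mg/kg in this assay, at which 2 of the 3 values shown sit, bound the two values from one side only.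

Compound 3 `Cn1c(-c2ccccc2F)nnc1[S+](C)[O-]` carries a different core; the difference between the two cores is not broken down here. In this assay compound 3 gives > 200 mg/kg, again a limit and not a number. Compound 4 `Cn1c(-c2ccccc2F)nnc1S(C)(=O)=O` awaits measurement. It stands to compound 3 as a group of 4 heavy atoms (1 carbon, 2 oxygen, 1 sulfur; no ring) in place of a group of 3 heavy atoms (1 carbon, 1 oxygen, 1 sulfur; no ring), on an aromatic carbon, the same kind of change as that from compound 1 to compound 2, here made on the core of compound 3 rather than on the core of compound 1.

For compound 4 the step of a number no higher from compound 3 to compound 4 (the limit leaves the size open) is expected to be small, resting on the step that the two limits leave unreadable from compound 1 to compound 2 in which the same kind of change gave no readable gain. Compound 4 is thus estimated at 200 mg/kg, between 100 mg/kg and 400 mg/kg, and a reading that is only a limit is expected to be the most likely outcome.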

Compound 4, dose for half-maximal effect: > 100 mg/kg
Compound 4 was reported as a limit (the forecaster's own chance of this, stated with the estimate: 85%); the middle value is on the limit's open side.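

In this assay compound 4 gives > 100 mg/kg, a limit and not a number. Compound 3 also stands at a limit, so no step can be read between compound 3 and compound 4. With all four readings being limits, the compounds shown leave open what dose any of them needs in this assay, and whether methylsulfonyl changes that dose on either core.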